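Imidazoline series: methoxyimine in place of the pyrimidinyl ring

A few compounds are considered here, and "the series" means these few. Any claim that something is new, unique, unknown or untested is made for them only; others in the source may bear on it.

Compound 2 `c1cnc(-c2ccccc2NCC2=NCCN2)nc1` gives 417 nM in an assay for binding affinity to Alpha-1D adrenergic receptor (Homo sapiens) (a higher number here means a weaker inhibitor, a lower number a stronger inhibitor), the highest of the two numbers recorded so far. Its nearest neighbour is compound 1 `c1ccc(-c2ccccc2NCC2=NCCN2)nc1`, which gives 117 nM in this assay; the step from pyridin-2-yl to pyrimidin-2-yl on the aromatic carbon brought a 3.6-fold higher number from compound 1 to compound 2 (0.55 log units; beyond the scatter). Compound 3 `CO/N=C/c1ccccc1NCC1=NCCN1` is not yet measured. It differs from compound 2 in one place: a group of 4 heavy atoms (2 carbon, 1 nitrogen, 1 oxygen; no ring) in place of a group of 6 heavy atoms (4 carbon, 2 nitrogen; one six-membered aromatic ring with 2 hetero atoms), on an aromatic carbon. Among the compounds with values here, no measured step involves the methoxyimine group or the loss of the aromatic ring, so the change is only loosely informed by the existing step, which shows that altering the group on this carbon shifts the number by a modest amount. Compound 3 is therefore expected to land near compound 2, with a wide range; the estimate is 350 nM (70 nM to 1800 nM), corresponding to an expected 1.2-fold lower number from compound 2 to compound 3 (0.08 log units; within the scatter).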

Compound 3, half-maximal inhibitory concentration: 42.7 nM
The estimate for compound 3 lay 8.2-fold (0.91 log units) above the measured number, outside the stated range (below it).
By their numbers in this assay, from the lowest: compound 3; then compound 1; then compound 2.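

In this assay, the aromatic ring is not required on this aromatic carbon: the open-chain methoxyimine group, with no ring, replaces pyrimidin-2-yl with a 9.8-fold lower number from compound 2 to compound 3 (0.99 log units; beyond the scatter), and replaces pyridin-2-yl with a 2.7-fold lower number from compound 1 to compound 3 (0.44 log units; beyond the scatter). The earlier step only exchanged one six-membered aromatic ring for another, whereas these two steps show that a smaller group without a ring gives the lowest number of the three, with both steps beyond the scatter. No measurement at hand explains this difference.

As far as these compounds go, it remains open whether the lower number follows from the imine double bond, the terminal methoxy group or the absence of a ring. A hydroxyimine, an ethoxyimine or an acetyl group on the same carbon would help separate these parts.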